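Swapping naphthalen-2-yl for phenyl on a shared core

This account rests on a few compounds, and the source may have more. Where it says the series, first, only, none or still open, it means among the compounds named here.

For the measured compounds named here, in a functional assay (aorta) with Oryctolagus cuniculus as the target (on this read-out lower numbers stand for tighter binding and higher numbers for weaker binding), three compounds on one shared core have numbers so far: compound 1 `N#Cc1ccc(OCCCN2CCC(C(c3ccc(F)cc3)c3ccc(F)cc3)CC2)cc1` reads 5.01 nM and compound 2 `CC(=O)Nc1ccc(OCCCN2CCC(C(c3ccc(F)cc3)c3ccc(F)cc3)CC2)cc1` reads 12.6 nM while compound 3 `Fc1ccc(C(c2ccc(F)cc2)C2CCN(CCCOc3ccc4ccccc4c3)CC2)cc1` reads 7.94 nM in the same test. The number of compound 3 falls between the other two, and its gap to each lies within the scatter. Compound 4 `Fc1ccc(C(c2ccc(F)cc2)C2CCN(CCCOc3ccccc3)CC2)cc1` has phenyl in place of naphthalen-2-yl on an oxygen on a saturated carbon, a difference counted as phenyl in place of naphthalen-2-yl on an oxygen on a saturated carbon and still unmeasured. The nearest evidence comes from swaps of the group on that same oxygen: a 1.6-fold higher number from compound 1 to compound 3 (0.20 log units; within the scatter) and a 1.6-fold lower number from compound 2 to compound 3 (0.20 log units; within the scatter) are both within the scatter. Only a 2.5-fold higher number from compound 1 to compound 2 (0.40 log units; beyond the scatter) goes beyond it, and that step is modest. Going by the values given here, no measured compound carries plain phenyl there, so this is an extrapolation. The expected result is a 1.1-fold higher number from compound 3 to compound 4 (0.05 log units; within the scatter) and so no clear shift in either direction. Compound 4 is estimated at 9 nM with an expected range from 4 nM to 22 nM as its likely span.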

Compound 4, dissociation constant: 1.59 nM
For compound 4 the middle estimate is 5.7-fold (0.75 log units) above the measured one, and the stated range ends above it.
By their numbers in this assay, from the lowest: compound 4; then compounds 1, 3 and 2 (each within the scatter of the next, the first and the last beyond it).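

In this assay, phenyl in place of naphthalen-2-yl on this oxygen, with one aromatic ring instead of two, gives a 5.0-fold lower number from compound 3 to compound 4 (0.70 log units; beyond the scatter) and lies beyond the scatter, whereas both earlier swaps involving naphthalen-2-yl stayed within it. Groups on the phenyl ring count as well: hydrogen in place of acetamido gives a 7.9-fold lower number from compound 2 to compound 4 (0.90 log units; beyond the scatter) and hydrogen in place of cyano gives a 3.2-fold lower number from compound 1 to compound 4 (0.50 log units; beyond the scatter), so among these compounds the plain phenoxy group reads lowest, with every other group tried here reading higher. Nothing available here accounts for this shift.

Still open, as far as these compounds go, is how a phenyl ring carrying a methoxy group or an amine would read in this test. Also open, from the compounds shown here alone, is whether plain phenoxy keeps its lead on a longer chain.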